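Aryl Swaps at the Hydrazone Carbon on a Shared Core

This account rests on a few compounds, and the source may have more. Where it says the series, first, only, none or still open, it means among the compounds named here.

Compound 1 `CCCSc1nc(N/N=C/c2ccccc2F)c2nnn(Cc3ccccc3)c2n1`: > 64000 nM
Compound 2 `CCCSc1nc(N/N=C/c2cccnc2)c2nnn(Cc3ccccc3)c2n1`: 58700 nM
Compound 3 `CCCSc1nc(N/N=C/c2ccc([N+](=O)[O-])cc2)c2nnn(Cc3ccccc3)c2n1`: 11000 nM

Three compounds with one shared core were tested in a functional assay on MCF7 cells (Homo sapiens) for antiproliferative activity, read by MTT assay, with a stated time of 72 h; a lower number here means a stronger inhibitor, a higher number a weaker inhibitor. For compound 1 the reading > 64000 nM is a limit of the assay, not a number. Compound 2 gives 58700 nM and compound 3 gives 11000 nM, the lowest of the two numbers shown. The measured steps onto it are a 5.3-fold lower number from compound 2 to compound 3 (0.73 log units; beyond the scatter) and an at least 5.8-fold lower number from compound 1 to compound 3 (0.76 log units; beyond the scatter), both changes of the aryl group on the same carbon and both modest.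

Compound 4 `CCCSc1nc(N/N=C/c2ccc3ccccc3c2)c2nnn(Cc3ccccc3)c2n1` is not yet measured. It differs from compound 3 by naphthalen-2-yl in place of 4-nitrophenyl on a carbon with a double bond to nitrogen. For the measured compounds named here, no measured step involves naphthalen-2-yl, and the earlier aryl swaps were modest, so the step for compound 4 is expected to be a 1.4-fold higher number from compound 3 to compound 4 (0.13 log units; within the scatter), with no direction beyond the scatter. Compound 4 is therefore estimated at 15000 nM, from 4000 nM to 60000 nM.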

Compound 4, half-maximal inhibitory concentration: > 64000 nM
Compound 4: a limit, no number (the forecaster's own chance of this, stated with the estimate: 15%); middle value at least 4.2-fold (0.63 log units) from the limit.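

The reading for compound 4 is a limit of the assay, not a number. In this assay, naphthalen-2-yl in place of 4-nitrophenyl gives an at least 5.8-fold higher number from compound 3 to compound 4 (0.76 log units; beyond the scatter), so the lower number seen with 4-nitrophenyl on this carbon does not carry over to an aryl group of two carbon-only rings. Against pyridin-3-yl the change gives an at least 1.0-fold higher number from compound 2 to compound 4 (0.03 log units; that floor lies within the scatter), a floor within the scatter, and the step between compound 1 and compound 4 cannot be read because both readings are limits: the limit of > 64000 nM in this assay, at which 2 of the 4 values shown sit.

Going by these compounds, whether a 4-aminophenyl or 4-methoxyphenyl group on this carbon would match compound 3 stays open. So does how far compound 4 lies beyond its limit.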